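This account rests on a few compounds, and the source may have more. Where it says the series, first, only, none or still open, it means among the compounds named here.

Within the data shown here, in a functional assay on CAPAN-1 cells (Homo sapiens) for antiproliferative activity, with a stated time of 72 h (a lower number here means a stronger inhibitor, a higher number a weaker inhibitor), compound 2 `Nc1ncnn2c([C@@H]3O[C@H](CO)[C@@H](O)[C@H]3O)cc(C#Cc3cccs3)c12` gives 32000 nM, the higher of the two numbers so far, while compound 1 `CCCC#Cc1cc([C@@H]2O[C@H](CO)[C@@H](O)[C@H]2O)n2ncnc(N)c12` gives 20 nM. Among the measured compounds shown here, the only measured step, a large one, is a 1600-fold higher number from compound 1 to compound 2 (3.20 log units; beyond the scatter), with thiophen-2-yl in place of propyl on a triple-bonded carbon. Compound 3 `Nc1ncnn2c([C@@H]3O[C@H](CO)[C@@H](O)[C@H]3O)cc(C#Cc3ccccc3)c12` changes that same place again: phenyl in place of thiophen-2-yl on a triple-bonded carbon. This swaps one aromatic ring for another, whereas the large step replaced a propyl chain with a ring, so no change beyond the scatter is expected, in either direction. The expected step is a 1.1-fold lower number from compound 2 to compound 3 (0.03 log units; within the scatter). For compound 3 the estimate is 30000 nM, with an expected range of 8000 nM to 100000 nM.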

Compound 3, half-maximal inhibitory concentration: 37700 nM
Compound 3: the middle estimate sits 1.3-fold (0.10 log units) below what was measured, within the range that was stated.
By their numbers in this assay, from the lowest: compound 1; then compounds 2 and 3 (each within the scatter of the next).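

In this assay, changing one aromatic ring for another on the triple-bonded carbon shows no real effect (a 1.2-fold higher number from compound 2 to compound 3 (0.07 log units; within the scatter)). Replacing propyl with phenyl gives a 1900-fold higher number from compound 1 to compound 3 (3.28 log units; beyond the scatter), so the large rise is not confined to thiophen-2-yl: both aromatic rings stand far from propyl at this position. On these data alone, whether a longer chain such as pentyl, or a propyl chain ending in an amine, would keep a number close to that of compound 1 remains open. No measurement shown here explains the gap between propyl and the two rings.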